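Chloro to methyl on the aromatic ring

The source may report more compounds than this note shows. Statements on the series, on what has been measured and on what is new or still open speak of the compounds shown alone.

For the measured compounds named here, in an ADME assay on HaCaT cells (Homo sapiens) for inhibition, read by sulforhodamine B assay, with a stated time of 48 h (on this read-out lower numbers stand for stronger inhibition of growth and higher numbers for weaker inhibition of growth), compound 1 (`S=C(N/N=C/c1cccs1)Nc1ccc(Cl)cc1`) gives 14700 nM and holds the lowest of the three numbers so far, beyond the scatter of the other two. Compound 2 (`S=C(N/N=C/c1cccs1)Nc1cccnc1`) stands at 45400 nM and compound 3 (`S=C(N/N=C/c1cccs1)Nc1cccc2ccccc12`) at 82400 nM on the same read-out. Compound 4 (`Cc1ccc(NC(=S)N/N=C/c2cccs2)cc1`) carries methyl in place of chloro on an aromatic carbon. Going by the values given here, no measured pair isolates this exchange. Among the compounds with values here, with compound 1 at 14700 nM as the lowest value so far, a rise is the likelier direction. The step of a 1.7-fold higher number from compound 1 to compound 4 (0.23 log units; within the scatter) is expected to be a small rise in the number. Compound 4 is estimated at 25000 nM with an expected range of 10000 nM to 60000 nM for now.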

Compound 4, concentration for 50% growth inhibition: 17600 nM
Compound 4: middle estimate off by 1.4-fold (0.15 log units), on the high side; the measured number falls inside the stated range.
By their numbers in this assay, from the lowest: compounds 1 and 4 (each within the scatter of the next); then compounds 2 and 3 (each within the scatter of the next).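

In this assay the exchange of chloro for methyl on an aromatic carbon, para to a large group, leaves the number within the scatter (a 1.2-fold higher number from compound 1 to compound 4 (0.08 log units; within the scatter)). For the compounds shown here, this is the first pair that differs in one place, and it shows that chlorine is not required at this position to hold the level of compound 1. Nothing measured here explains why the two groups read alike.

Still open, on these data alone, is whether an amine, a carboxylic acid or a longer chain at this position would also read alike. Plain hydrogen on the same carbon would show whether any group is needed there at all.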